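The source may report more compounds than this note shows. Statements on the series, on what has been measured and on what is new or still open speak of the compounds shown alone.

In a functional assay for antagonist activity at C-X-C chemokine receptor type 3 (Homo sapiens) (on this read-out higher numbers stand for weaker inhibition and lower numbers for stronger inhibition), compound 3 `CNC(=O)c1cnc(N2CCN(C3CCN(Cc4ccc(C)cc4)CC3)[C@@H](C)C2)c(Cl)c1` gives 87 nM, the lowest of the three numbers; compound 1 `CNC(=O)c1cnc(N2CCN(C3CCN(Cc4ccco4)CC3)[C@@H](C)C2)c(Cl)c1` gives 8100 nM and compound 2 `CNC(=O)c1cnc(N2CCN(C3CCN(Cc4ccc[nH]4)CC3)[C@@H](C)C2)c(Cl)c1` gives 8060 nM. Compound 4 `CNC(=O)c1cnc(N2CCN(C3CCN(C(F)(F)F)CC3)[C@@H](C)C2)c(Cl)c1` differs from compound 3 by trifluoromethyl in place of 4-methylbenzyl on an amine nitrogen in a ring. Among the compounds with values here, no measured step removes the aromatic ring from that position altogether. The nearest evidence is a 93-fold lower number from compound 1 to compound 3 (1.97 log units; beyond the scatter) and a 93-fold lower number from compound 2 to compound 3 (1.97 log units; beyond the scatter), whereas a 1.0-fold lower number from compound 1 to compound 2 (0.00 log units; within the scatter). Both large steps show that the 4-methylbenzyl group accounts for the advantage of compound 3 over compound 1 and compound 2, so exchanging it for trifluoromethyl is expected to give a large step back toward weaker inhibition, a 69-fold higher number from compound 3 to compound 4 (1.84 log units; beyond the scatter). Compound 4 is therefore estimated at 6000 nM in this assay, within 1200 nM to 30000 nM.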

Compound 4, half-maximal inhibitory concentration: 63 nM
Compound 4: middle estimate off by 95-fold (1.98 log units), on the high side; measured number below the stated range.
By their numbers in this assay, from the lowest: compounds 4 and 3 (each within the scatter of the next); then compounds 2 and 1 (each within the scatter of the next).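

In this assay, a ring on this amine nitrogen proves unnecessary: trifluoromethyl, which has no ring and fewer heavy atoms, matches 4-methylbenzyl (a 1.4-fold lower number from compound 3 to compound 4 (0.14 log units; within the scatter)). Trifluoromethyl also keeps the whole advantage over (furan-2-yl)methyl (a 130-fold lower number from compound 1 to compound 4 (2.11 log units; beyond the scatter)) and over (1H-pyrrol-2-yl)methyl (a 130-fold lower number from compound 2 to compound 4 (2.11 log units; beyond the scatter)). No measurement offered here explains this result. From the compounds shown here alone, whether a plain methyl, a cyclopropyl or an unsubstituted benzyl on this nitrogen would group with compound 3 and compound 4 or with compound 1 and compound 2 stays open.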